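A few compounds are considered here, and "the series" means these few. Any claim that something is new, unique, unknown or untested is made for them only; others in the source may bear on it.

Compound 1 `c1ccc2c(c1)CN[C@@H](CN(CC1CCNCC1)[C@H]1CCCc3cccnc31)C2` is the weakest of the three measured compounds in an ADME assay on microsomes from liver (Mus musculus) for metabolic stability, read by LC-MS, with a stated time of 10 min, tested at 0.5 uM (a lower number here means that less of the compound is left, a higher number that more of the compound is left), where compound 1 gives 13%. Compound 2 `c1cnc(CN(CCCN2CCNCC2)[C@H]2CCCc3cccnc32)nc1` gives 78%, and compound 3 `c1ccc2c(c1)CN[C@H](CN(CCCN1CCNCC1)[C@H]1CCCc3cccnc31)C2` gives 88%. Compound 4 `c1ccc2c(c1)CN[C@@H](CN(CCCCN1CCNCC1)[C@H]1CCCc3cccnc31)C2` differs from compound 1 in one place: 3-(piperazin-1-yl)propyl in place of piperidin-4-yl on a saturated chain carbon bound to an amine nitrogen. Within the data shown here, no measured step makes exactly this change. Among the measured compounds shown here, the only measured step, a number 10 percentage points higher from compound 2 to compound 3 (within the scatter), alters a different part of the core, so it does not bear directly on it. Compound 3, which carries a chain ending in piperazin-1-yl, lies far above compound 1, and this points to a large rise. Compound 4 is therefore expected to give 70%, between 40% and 92%, a step of a number 57 percentage points higher from compound 1 to compound 4 (beyond the scatter).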

Compound 4, percent of the compound remaining: 96%
Compound 4: the middle estimate sits 26 percentage points below what was measured; the whole stated range lies below it.
By their numbers in this assay, from the lowest: compound 1; then compounds 2, 3 and 4 (each within the scatter of the next, the first and the last beyond it).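

In this assay, 3-(piperazin-1-yl)propyl in place of piperidin-4-yl on a saturated chain carbon bound to an amine nitrogen gives a number 83 percentage points higher from compound 1 to compound 4 (beyond the scatter) and so shows that this position can change the amount of compound left very strongly. The earlier compounds shown here offered no measured step at this position. Nothing available explains this rise. This one change alters both the ring and the chain, so the compounds shown leave open which of the two matters. A 4-(piperidin-4-yl)butyl group would keep the ring of compound 1 on the longer chain.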